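Dihydroxyphenyl in place of methylphenyl on a fused core

A few compounds are considered here, and "the series" means these few. Any claim that something is new, unique, unknown or untested is made for them only; others in the source may bear on it.

Measured so far:
compound 1, `CCC1=C(O)c2c(oc(-c3cccc(C)c3)cc2=O)C(CC)(CC)C1=O`: 3.69 uM
compound 2, `CCC1=C(O)c2c(oc(-c3cccc(C(F)(F)F)c3)cc2=O)C(CC)(CC)C1=O`: 5.42 uM

Compound 1 carries a 3-methylphenyl group on the shared core. In a functional assay on KBVIN cells (Homo sapiens) for antiproliferative activity, read by sulforhodamine B assay, with a stated time of 3 days (a lower number here means that less compound is needed, a higher number that more compound is needed for the effect), compound 1 gives 3.69 uM. Compound 2 differs from compound 1 only by a trifluoromethyl in place of methyl on an aromatic carbon, and in this assay compound 2 gives 5.42 uM; the step of a 1.5-fold higher number from compound 1 to compound 2 (0.17 log units; within the scatter) is the only one on record. Compound 1 thus holds the lower of the two numbers, but the gap to compound 2 stays within the scatter, so no order between them can be claimed.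

Compound 3, `CCC1=C(O)c2c(oc(-c3ccc(O)c(O)c3)cc2=O)C(CC)(CC)C1=O`, has not yet been measured. It differs from compound 1 by 3,4-dihydroxyphenyl in place of 3-methylphenyl on an aromatic carbon. Going by the values given here, no measured step bears on this change: the only step on record swaps one substituent on the same ring for another of similar kind and was within the scatter, while here two hydroxyl groups replace a methyl. The expectation for compound 3 therefore rests on the narrow range seen so far, and the step of a 1.4-fold higher number from compound 1 to compound 3 (0.13 log units; within the scatter) is expected to stay modest in either direction. For compound 3 the estimate in this assay is 5 uM, with a range from 1.5 uM to 16 uM.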

Compound 3, concentration for half-maximal effect: 5.41 uM
Compound 3: middle estimate off by 1.1-fold (0.03 log units), on the low side, within the range that was stated.
By their numbers in this assay, from the lowest: compounds 1, 3 and 2 (each within the scatter of the next).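

In this assay, putting 3,4-dihydroxyphenyl in place of 3-methylphenyl on the aromatic carbon next to the ring oxygen gives a 1.5-fold higher number from compound 1 to compound 3 (0.17 log units; within the scatter). The earlier step exchanged only methyl for trifluoromethyl on the phenyl ring, whereas this change brings in 2 hydrogen-bond donors and 2 hydrogen-bond acceptors where the leaving group had none, and still no difference can be read in this assay, so this position of the shared core has now accepted a far larger change in the phenyl substituents without a step beyond the scatter. Nothing at hand explains why the number holds across this exchange.

The compounds shown leave open whether a phenyl ring with a single hydroxyl group, at either of the two places occupied in compound 3, would read the same in this assay. They also leave open whether an amine or a carboxylic acid on the phenyl ring, or a longer alkyl chain in place of that ring, would stay within the same narrow range of numbers.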